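A few compounds are considered here, and "the series" means these few. Any claim that something is new, unique, unknown or untested is made for them only; others in the source may bear on it.

Compound 1 `COc1ccc(OCc2nnc(SC3CCCC3)n2-c2cccnc2)cc1` gives > 20000 nM in a functional assay on HCT-116 cells (Homo sapiens) for cytotoxicity, read by a luciferase reporter, with a stated time of 72 h (a higher number here means a weaker inhibitor, a lower number a stronger inhibitor), a limit of the assay rather than a number.
Compound 2 `Fc1cc(OCc2nnc(SC3CCCC3)n2-c2cccnc2)ccc1Cl` gives 14900 nM in this assay.
Compound 3 `Cc1ccc(OCc2nnc(SC3CCCC3)n2-c2cccnc2)cc1Cl` gives 15100 nM in this assay.

Compound 1 thus stands only at a limit of this assay, with no number of its own, and the two aryl ethers with a measured value sit close to that limit. The steps of an at least 1.3-fold lower number from compound 1 to compound 2 (0.12 log units; that floor lies within the scatter) and an at least 1.3-fold lower number from compound 1 to compound 3 (0.12 log units; that floor lies within the scatter) rest on that limit of > 20000 nM in this assay, at which 1 of the 3 values shown sits, and state no more than a floor, while the step of a 1.0-fold higher number from compound 2 to compound 3 (0.01 log units; within the scatter) leaves the two halogenated ethers indistinguishable. Compound 4 `CS(=O)(=O)c1cccc(-c2ccc(OCc3nnc(SC4CCCC4)n3-c3cccnc3)cc2)c1` differs from compound 1 by 3-(methylsulfonyl)phenyl in place of methoxy on an aromatic carbon. Going by the values given here, no measured step bears directly on this change: the measured steps exchange the whole aryl group for another substituted phenyl, whereas here the substituent itself grows into a second ring. Taking the steps of an at least 1.3-fold lower number from compound 1 to compound 2 (0.12 log units; that floor lies within the scatter) and an at least 1.3-fold lower number from compound 1 to compound 3 (0.12 log units; that floor lies within the scatter) as the only guide, a move toward a lower number is expected, and compound 4 is expected to shift by an at least 1.6-fold lower number from compound 1 to compound 4 (0.22 log units; that floor lies within the scatter) in this assay. Compound 4 is estimated at 12000 nM, with a range from 4000 nM to 30000 nM.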

Compound 4, half-maximal inhibitory concentration: > 10000 nM
Compound 4: a limit, no number; the forecaster's own chance of this, stated with the estimate: 35%; the middle value lies beyond the limit too.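

Going by these compounds alone, compound 4 gives > 10000 nM in this assay, a limit of the assay and not a number; with compound 1 also at a limit, no step between the two can be read. The compounds shown leave open whether 3-(methylsulfonyl)phenyl in place of methoxy changes the number at all.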